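Replacing the 2-carboxyethyl Chain with Hydrogen

The compounds below may be only part of what the source reports. "The series", "measured", "known", "first", "only" and "open" are said of these compounds alone.

Two compounds set the scene. In a functional assay on NCI-H441 cells (Homo sapiens) for antiproliferative activity, with a stated time of 24 h (a higher number here means a weaker inhibitor, a lower number a stronger inhibitor), compound 1 (`O=C1/C(=C/c2ccccc2Br)CNC/C1=C\c1ccccc1Br`) gives 6000 nM, while compound 2 (`O=C(O)CCC(=O)N1C/C(=C\c2ccccc2F)C(=O)/C(=C/c2ccccc2F)C1`) gives 69000 nM. Compound 2 therefore holds the higher of the two numbers, and the gap to compound 1 lies beyond the scatter, making it the weaker inhibitor of this pair.

Compound 3 (`O=CN1C/C(=C\c2ccccc2F)C(=O)/C(=C/c2ccccc2F)C1`) departs from compound 2 at a single place: hydrogen in place of 2-carboxyethyl on a carbonyl carbon. Hydrogen stands in place of 2-carboxyethyl on a carbonyl carbon whose other neighbour is an amide-type nitrogen in a ring, turning (2-carboxyethyl)carbonyl into formyl.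

Going by the values given here, no measured step shows this change, so the forecast rests on thin evidence. Compound 1 also lacks the 2-carboxyethyl group and gives 6000 nM, although it differs from compound 2 elsewhere as well. A move towards stronger inhibition in this assay is therefore expected, beyond the scatter, and the estimated change is a 7.7-fold lower number from compound 2 to compound 3 (0.88 log units; beyond the scatter). For compound 3 the estimated value is 9000 nM, with an expected range from 2500 nM to 30000 nM.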

Compound 3, half-maximal inhibitory concentration: 49000 nM
The estimate for compound 3 lay 5.4-fold (0.74 log units) below the measured number; the measured number lies above the stated range.
By their numbers in this assay, from the lowest: compound 1; then compounds 3 and 2 (each within the scatter of the next).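

In this assay, going by these compounds alone, the exchange of 2-carboxyethyl for hydrogen on the carbonyl carbon gives a 1.4-fold lower number from compound 2 to compound 3 (0.15 log units; within the scatter) and is the first direct reading of this change. On this carbonyl carbon, whose other neighbour is an amide-type nitrogen in a ring, the whole 2-carboxyethyl chain, carboxylic acid included, can therefore be exchanged for hydrogen without a shift beyond the scatter, at least in this one pair. The shared fluorinated frame of compound 2 and compound 3 stays the same throughout, and no measurement shown here explains why the number holds when the chain leaves.

Within the data shown here, compound 1 (6000 nM) differs from compound 3 in more than one place and has no single-change step to either compound, so its value cannot be assigned to any one feature of its structure. Also open, going by these compounds, is whether a methyl group, an amine or a longer chain on that same carbonyl carbon would leave the number in this assay within the scatter too, since one step says nothing about groups of other kinds there.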